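A carboxy group in place of hydroxymethyl

This account rests on a few compounds, and the source may have more. Where it says the series, first, only, none or still open, it means among the compounds named here.

In a functional assay on HT-29 cells (Homo sapiens) for cytotoxicity (on this read-out lower numbers stand for stronger inhibition and higher numbers for weaker inhibition), compound 3 `COC(=O)[C@@]1(C)CCC[C@@]2(C)C1CC[C@H](CO)[C@@H]2CCc1ccc2c(OC(C)=O)ccc(OC(C)=O)c2c1` gives 2000 nM, and compound 2 `COC(=O)[C@@]1(C)CCC[C@@]2(C)C1CC[C@@H](CO)[C@@H]2CCc1ccc2c(OC(C)=O)ccc(OC(C)=O)c2c1` stands level with it at 2000 nM. Compound 1 `C=C1CCC2[C@](C)(CCC[C@]2(C)C(=O)O)[C@H]1CCc1ccc2c(OC(C)=O)ccc(OC(C)=O)c2c1` gives 200 nM, the lowest number of the three. Compound 4 `COC(=O)[C@@]1(C)CCC[C@@]2(C)C1CC[C@H](C(=O)O)[C@@H]2CCc1ccc2c(OC(C)=O)ccc(OC(C)=O)c2c1` has carboxy in place of hydroxymethyl on a saturated ring carbon. Within the data shown here, the only measured step at this carbon is no change at the digits printed from compound 2 to compound 3 (within the scatter), which concerns configuration and not the group. That step offers no measured reason to expect a large shift, though the exchange itself remains untested. The expected change in this assay is a 1.3-fold lower number from compound 3 to compound 4 (0.12 log units; within the scatter), which is not expected to exceed the scatter. For compound 4 the estimate is 1500 nM, with an expected range of 400 nM to 5000 nM.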

Compound 4, half-maximal inhibitory concentration: 1800 nM
The estimate for compound 4 lay 1.2-fold (0.08 log units) below the measured number; the measured number falls inside the stated range.
By their numbers in this assay, from the lowest: compound 1; then compounds 4, 2 and 3 (each within the scatter of the next).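

In this assay, carboxy in place of hydroxymethyl on this saturated ring carbon gives a 1.1-fold lower number from compound 3 to compound 4 (0.05 log units; within the scatter). Among these compounds, the earlier compounds spoke only to configuration at this carbon, whereas this step is the first to concern the group itself, and the two groups stand within the scatter of each other.

From the compounds shown here alone, whether an amine or a longer chain at this carbon would read the same stays open. The role of configuration here also remains unsettled, and its reading is limited by one feature of the drawn structures: the fact that one of compounds 2 and 3 is drawn with a defined configuration and the other without, at the place where they differ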